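The source may report more compounds than this note shows. Statements on the series, on what has been measured and on what is new or still open speak of the compounds shown alone.

Going by the values given here, compound 2 `COc1ccc(-c2nc(N)c(Oc3ccccc3OC)c(Cl)n2)cc1` gives 47800 nM in a functional assay on B16 cells (Mus musculus) for cytotoxicity, read by CCK-8 assay, with a stated time of 24 h (on this read-out higher numbers stand for weaker inhibition and lower numbers for stronger inhibition), the highest of the two numbers so far; compound 1 `COc1ccccc1Oc1c(N)nc(-c2ccc(C)cc2)nc1Cl` gives 17400 nM. Among the compounds with values here, the only step to hand, a 2.7-fold higher number from compound 1 to compound 2 (0.44 log units; beyond the scatter), shows that methoxy in place of methyl raised the number. Compound 3 `COc1ccccc1Oc1c(N)nc(-c2ccc(I)cc2)nc1Cl` carries iodo in place of methoxy on an aromatic carbon. Iodo, like methyl, carries no hydrogen-bond acceptor, so undoing the methoxy is expected to bring the number back down by roughly the size of that step, giving an estimated 3.2-fold lower number from compound 2 to compound 3 (0.50 log units; beyond the scatter). Compound 3 is therefore expected to give about 15000 nM, within 5000 nM to 45000 nM.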

Compound 3, half-maximal inhibitory concentration: 5400 nM
For compound 3 the middle estimate is 2.8-fold (0.44 log units) above the measured one; the range from low to high includes it.
By their numbers in this assay, from the lowest: compound 3; then compound 1; then compound 2.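

In this assay, iodo at this position gives the lowest number of the three compounds, with an 8.9-fold lower number from compound 2 to compound 3 (0.95 log units; beyond the scatter) and a 3.2-fold lower number from compound 1 to compound 3 (0.51 log units; beyond the scatter) as well. The position therefore does more than separate methoxy from methyl: iodo does not merely match methyl but goes beyond it, so the three groups fall into a clear order. No evidence here bears on why iodo lowers the number. As far as these compounds go, whether chloro, bromo, an amine or a carboxylic acid at this position would fall in line with that order remains open.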